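Oxan-2-yl for ethyl on the pyrazole nitrogen of compound 3

The compounds below may be only part of what the source reports. "The series", "measured", "known", "first", "only" and "open" are said of these compounds alone.

Three amide-linked biaryls with the shared core have been measured in an assay on isolated protein for inhibition of Discoidin domain-containing receptor 2 (Homo sapiens), read by ELISA, with a stated time of 60 min; on this read-out higher numbers stand for weaker inhibition and lower numbers for stronger inhibition. Compound 1 `Cc1ccc(C(=O)Nc2ccc(CN3CCN(C)CC3)cc2)cc1-c1ccc2cn[nH]c2c1` gives 6.7 nM in this assay. Compound 2 `Cc1ccc(C(=O)Nc2cccc(C(F)(F)F)c2)cc1-c1ccc2c(-c3ccc(N4CCN(C)CC4)cc3)n[nH]c2c1` carries a methylpiperazinyl-phenyl group on the core and gives 8.8 nM. Compound 3 `CCn1cc(-c2n[nH]c3cc(-c4cc(C(=O)Nc5cccc(C(F)(F)F)c5)ccc4C)ccc23)cn1` carries a 1-ethyl-1H-pyrazol-4-yl group in the same position and gives 2.6 nM, the lowest of the three numbers; its gaps to compound 1 and to compound 2 both lie beyond the usual scatter, so within this small set compound 3 is the strongest inhibitor.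

Compound 4 `Cc1ccc(C(=O)Nc2cccc(C(F)(F)F)c2)cc1-c1ccc2c(-c3cnn(C4CCCCO4)c3)n[nH]c2c1` differs from compound 3 in one place: oxan-2-yl in place of ethyl on an aromatic nitrogen. The trifluoromethyl-phenyl amide and the rest of the core are unchanged. Among the measured compounds shown here, no measured pair in the set shows a change of this kind, so there is no direct precedent to lean on; the substituent on the pyrazole nitrogen sits two ring bonds from the ring atom that bears the large group, at the outer edge of the molecule, and the values of compound 2 and compound 3 suggest that the core tolerates different groups in that region. The expected step from compound 3 to compound 4 is therefore small, a 1.9-fold higher number from compound 3 to compound 4 (0.28 log units; within the scatter), with no clear direction beyond the scatter. Compound 4 is estimated at 5 nM in this assay, with a range from 1.5 nM to 15 nM.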

Compound 4, half-maximal inhibitory concentration: 5.2 nM
The estimate for compound 4 lay 1.0-fold (0.02 log units) below the measured number; measured number inside the range.
By their numbers in this assay, from the lowest: compounds 3, 4, 1 and 2 (each within the scatter of the next, the first and the last beyond it).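

In this assay, among the compounds shown here, oxan-2-yl in place of ethyl on an aromatic nitrogen gives a 2.0-fold higher number from compound 3 to compound 4 (0.30 log units; within the scatter), the first step that can be read at this position. The change goes from ethyl, with 2 heavy atoms and no ring, to oxan-2-yl, with 6 heavy atoms, one six-membered non-aromatic ring and 1 hydrogen-bond acceptor, so this single pair shows that the added ring and acceptor leave the number within the scatter. The data at hand offer no measurement that would account for this result.

Open at this position is how the number responds to an amine such as a dimethylaminoethyl chain, to a carboxylic acid, to a longer chain such as n-butyl, or to a plain hydrogen on the pyrazole nitrogen. Also open, on these data alone, is whether the same ethyl to oxan-2-yl exchange reads the same way with an amide part other than the trifluoromethyl-phenyl group, such as the methylpiperazine-bearing amide part of compound 1.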